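The source may hold more compounds than are shown below. What is called first, only, known or untested is meant among the compounds shown, and "the series" means these compounds.

Among the measured compounds shown here, compound 2 `COc1ccc(C2CC(c3ccc4ccccc4c3)=NN2CC=O)cc1O` gives 2040 nM in a functional assay on PC-3 cells (Homo sapiens) for cytotoxicity, read by sulforhodamine B assay, with a stated time of 48 h (a higher number here means a weaker inhibitor, a lower number a stronger inhibitor), the highest of the three numbers measured so far. Compound 1 `COc1ccc(C2CC(c3ccc4ccccc4c3)=NN2CC=O)cc1OC` gives 1980 nM; a 1.0-fold higher number from compound 1 to compound 2 (0.01 log units; within the scatter). Compound 3 `O=CCN1N=C(c2ccc3ccccc3c2)CC1c1ccc2ccccc2c1` gives 200 nM, a far lower number. Compound 4 `O=CCN1N=C(c2ccc3ccccc3c2)CC1/C=C/c1ccccc1` has not yet been measured; it differs from compound 2 by 2-phenylethenyl in place of 3-hydroxy-4-methoxyphenyl on a saturated ring carbon. For the measured compounds named here, the only measured single step, from compound 1 to compound 2, touches a different part of the molecule and stays within the scatter, so it gives little guidance here. The values of compound 2 and compound 3 show that exchanging the 3-hydroxy-4-methoxyphenyl group for a different aromatic group went with a markedly lower number. Compound 4 is therefore expected to give about 700 nM, within 250 nM to 2500 nM, an estimated step of a 2.9-fold lower number from compound 2 to compound 4 (0.46 log units; beyond the scatter) toward a lower number.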

Compound 4, half-maximal inhibitory concentration: 19100 nM
For compound 4 the middle estimate is 27-fold (1.44 log units) below the measured one; measured number above the stated range.
By their numbers in this assay, from the lowest: compound 3; then compounds 1 and 2 (each within the scatter of the next); then compound 4.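

There is a 9.4-fold higher number from compound 2 to compound 4 (0.97 log units; beyond the scatter) in this assay when 2-phenylethenyl replaces 3-hydroxy-4-methoxyphenyl on this saturated ring carbon. A change here can therefore go with a higher number too, which compound 3 alone did not reveal. The swap alters several things at once, adding a double bond outside the aromatic ring and removing the oxygens, and no evidence here explains the result. Still open, as far as these compounds go, is which of these changes matters, something a saturated 2-phenylethyl group or a plain phenyl could help separate.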